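A few compounds are considered here, and "the series" means these few. Any claim that something is new, unique, unknown or untested is made for them only; others in the source may bear on it.

Of the compounds shown here, three built on one shared core have been tested in an ADME assay on L929 cells (Mus musculus) for cytotoxicity, with a stated time of 72 h; a higher number here means a weaker inhibitor, a lower number a stronger inhibitor. Compound 1 is `CCOC(=O)C(C)Oc1ccc2c(c1)B(O)OC2`. In this assay compound 1 reaches only a limit of the test, > 10 ug/mL. Compound 2 `CCOC(=O)C(CC)Oc1ccc2c(c1)B(O)OC2` differs from compound 1 by methyl in place of hydrogen on a saturated chain carbon, two bonds along the chain from a carbonyl carbon and an oxygen on an aromatic ring. In this assay compound 2 likewise gives only a limit, > 10 ug/mL. The step that the two limits leave unreadable from compound 1 to compound 2 therefore cannot be sized. Compound 3 `CC(=O)C(C)Oc1ccc2c(c1)B(O)OC2` differs from compound 1 in its core by methyl in place of ethoxy on a carbonyl carbon. In this assay compound 3 also stops at a limit, > 10 ug/mL. All that has been seen is the limit of > 10 ug/mL in this assay, at which 3 of the 3 values shown sit.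

Compound 4 `CC(=O)C(C)(C)Oc1ccc2c(c1)B(O)OC2` has not yet been measured; it differs from compound 3 by methyl in place of hydrogen on a saturated chain carbon bound to a carbonyl carbon, an oxygen on an aromatic ring and a saturated chain carbon. This is the same kind of change as from compound 1 to compound 2, but the place differs: there the carbon sat two bonds along the chain from a carbonyl carbon and an oxygen on an aromatic ring, here it is bound to a carbonyl carbon, an oxygen on an aromatic ring and a saturated chain carbon. Because the limit of > 10 ug/mL in this assay, at which 3 of the 3 values shown sit, is the whole picture, compound 4 is expected to stay near that same limit, an estimated step that the limit leaves unreadable from compound 3 to compound 4 beside the unreadable earlier one. The estimate for compound 4 is 15 ug/mL, expected to fall between 6 ug/mL and 40 ug/mL.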

Compound 4, half-maximal inhibitory concentration: > 10 ug/mL
Compound 4 was reported as a limit; the forecaster's own chance of this, stated with the estimate: 85%; the middle value lies beyond the limit too.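

In this assay compound 4 also stops at a limit of the test, > 10 ug/mL. Compound 3 gave only a limit too, so no size can be read for the step between compound 3 and compound 4. The compounds shown leave open whether any of these changes alters cytotoxicity at all, for the whole picture remains this: the limit of > 10 ug/mL in this assay, at which 4 of the 4 values shown sit.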